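The source may hold more compounds than are shown below. What is called first, only, known or untested is meant among the compounds shown, and "the series" means these compounds.

Working notes on the series. The shared core is that of compound 1 `N#Cc1ccccc1COc1ccc([C@H]2CC[C@@H](C(N)=O)N2)cc1`, which in an ADME assay on a cell-free system (plasma, Rattus norvegicus) for protein binding (on this read-out higher numbers stand for a larger free fraction and lower numbers for a smaller free fraction), gives 0.12. Compound 2 `NC(=O)[C@@H]1CC[C@H](c2ccc(OCc3ccccc3)cc2)N1` stands on no single number here; in this assay its result is "not determined" (no result reported). Compound 3 `NC(=O)[C@@H]1CC[C@H](c2ccc(OCc3cccc(F)c3)cc2)N1` differs from compound 2 by fluoro in place of hydrogen on an aromatic carbon. Within the data shown here, no measured pair carries this difference, so the direction of the step from compound 2 to compound 3 in this assay cannot be read from the data; a shift no larger than the usual scatter is expected. Compound 3 is expected at 0.1, within 0.05 to 0.2, because compound 1 gives 0.12.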

Compound 3, unbound fraction: 0.033
Estimate against measurement, compound 3: 3.0-fold (0.48 log units) above, outside the stated range (below it).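

Putting 3-fluorophenyl in place of 2-cyanophenyl on the saturated chain carbon bound to an oxygen gives a 3.6-fold lower number from compound 1 to compound 3 (0.56 log units; beyond the scatter) in this assay, so a change at this position can move the free fraction beyond the scatter. The step from compound 2 to compound 3 cannot be read, as compound 2 has no number. No measurement at hand accounts for the shift.

Still open, on these data alone, is how much of the step belongs to the fluoro and how much to the nitrile. Also open, as far as these compounds go, is where a carboxylic acid or an amine on this aromatic ring would place the free fraction.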